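A few compounds are considered here, and "the series" means these few. Any claim that something is new, unique, unknown or untested is made for them only; others in the source may bear on it.

Measured compounds:
compound 1 `O=S(=O)(c1cccc(F)c1)c1cnc2c(F)cccc2c1-c1ccc(Cl)cc1`, 0.62 mL/min
compound 2 `O=S(=O)(c1cccc(F)c1)c1cnc2c(F)cccc2c1-c1ccccc1F`, 0.21 mL/min
compound 3 `COc1ccc(-c2c(S(=O)(=O)c3cccc(F)c3)cnc3c(F)cccc23)cc1`, 2.48 mL/min

In an ADME assay on microsomes from liver (Homo sapiens) for metabolic stability, tested at 2.5 uM (on this read-out higher numbers stand for fast clearance and lower numbers for slow clearance), compound 1 gives 0.62 mL/min, which places it second highest of the three numbers. Its nearest neighbour is compound 2 with 0.21 mL/min, a step of a 3.0-fold lower number from compound 1 to compound 2 (0.47 log units; beyond the scatter); the furthest is compound 3 with 2.48 mL/min, a step of a 4.0-fold higher number from compound 1 to compound 3 (0.60 log units; beyond the scatter). Between those two outer compounds the step is a 12-fold higher number from compound 2 to compound 3 (1.07 log units; beyond the scatter).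

Compound 4 `O=S(=O)(c1cc(Cl)cc(Cl)c1)c1cnc2c(F)cccc2c1-c1ccc(Cl)cc1` is not yet measured. It differs from compound 1 at the sulfonyl side of the shared core: 3,5-dichlorophenyl in place of 3-fluorophenyl on a sulfonyl sulfur

None of the three measured steps touches this position; all of them swap the aryl group on the aromatic carbon, where two modest steps and one large step appeared in this assay. The ring on the sulfonyl sulfur is the same in compounds 1 to 3, so nothing measured tells how it matters. The expectation for compound 4 is therefore uncertain, and the estimated step of a 1.6-fold higher number from compound 1 to compound 4 (0.21 log units; within the scatter) is taken as a modest rise. Compound 4 is expected to give about 1 mL/min, with a range from 0.3 mL/min to 3 mL/min.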

Compound 4, intrinsic clearance in a liver preparation (reported as CLH), per the amount of preparation that the assay uses: 0.78 mL/min
For compound 4 the middle estimate is 1.3-fold (0.11 log units) above the measured one; the range from low to high includes it.
By their numbers in this assay, from the lowest: compound 2; then compounds 1 and 4 (each within the scatter of the next); then compound 3.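

In this assay the swap of 3-fluorophenyl for 3,5-dichlorophenyl on a sulfonyl sulfur gives a 1.3-fold higher number from compound 1 to compound 4 (0.10 log units; within the scatter) and so leaves compound 1 and compound 4 indistinguishable on this read-out. Within the data shown here, this is the first information about this position, and it contrasts with the swaps on the aromatic carbon, where even the smallest step, a 3.0-fold lower number from compound 1 to compound 2 (0.47 log units; beyond the scatter), lies beyond the scatter. Within this single pair, then, the ring on the sulfonyl sulfur can be exchanged without a measurable effect on clearance, although nothing available explains that result.

One pair cannot show whether the same holds for the whole position, since both rings are phenyl groups carrying only fluorine or chlorine, so a ring bearing an amine or a carboxylic acid, or a plain alkyl chain on the sulfur, could behave quite differently. From the compounds shown here alone, it also remains open whether 3,5-dichlorophenyl would behave the same way with 2-fluorophenyl or 4-methoxyphenyl on the aromatic carbon of the shared core, where the numbers span a much wider range.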